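Azole replacements on the shared core of compound 2

The source may hold more compounds than are shown below. What is called first, only, known or untested is meant among the compounds shown, and "the series" means these compounds.

Measured so far in a functional assay for activation of Alpha-1B adrenergic receptor (Homo sapiens), read by calcium flux; on this read-out lower numbers stand for an effect already at smaller amounts and higher numbers for an effect only at larger amounts of compound:
compound 1, `c1cncc(-c2ccccc2OCC2=NCCN2)c1`, gives 79.4 nM
compound 2, `c1c[nH]c(-c2ccccc2OCC2=NCCN2)c1`, gives 1 nM

Compound 2 holds the lowest of the two numbers in this assay. For the measured compounds named here, the only measured step is a 79-fold lower number from compound 1 to compound 2 (1.90 log units; beyond the scatter), an exchange of pyridin-3-yl for 1H-pyrrol-2-yl.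

Compound 3, `c1ccc(-c2ncc[nH]2)c(OCC2=NCCN2)c1`, differs from compound 2 in one place: 1H-imidazol-2-yl in place of 1H-pyrrol-2-yl on an aromatic carbon. Going by the values given here, no measured pair covers this exchange. The step of a 79-fold lower number from compound 1 to compound 2 (1.90 log units; beyond the scatter) bears on it only loosely, since it swapped a different aryl group for the pyrrole rather than altering the pyrrole itself; it shows that the group in this position can move the number strongly. Among the compounds with values here, with no closer precedent, compound 3 is expected to remain near compound 2, with a modest rise more likely than a fall, so the estimated step is a 4.0-fold higher number from compound 2 to compound 3 (0.60 log units; beyond the scatter). Compound 3 is therefore estimated at 4 nM, with a range from 1 nM to 30 nM.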

Compound 3, half-maximal effective concentration: < 100000 nM
Compound 3 ended at the assay's limit; the forecaster's own chance of this, stated with the estimate: 5%; the middle value is on the limit's open side.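

In this assay compound 3 gives < 100000 nM which is a limit of the assay and not a number, so the steps from compound 1 and from compound 2 to compound 3 cannot be read: the limit of < 100000 nM in this assay, at which 1 of the 3 values shown sits.

On these data alone, how far 1H-imidazol-2-yl in place of 1H-pyrrol-2-yl moves the number on the shared core stays open.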